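From Diethylamino to Cyclopropyl(methyl)amino on the Sulfonyl

The source may hold more compounds than are shown below. What is called first, only, known or untested is meant among the compounds shown, and "the series" means these compounds.

Of the compounds shown here, two have so far been measured in a functional assay on NT2 cells (Homo sapiens) for inhibition; a lower number here means a stronger inhibitor, a higher number a weaker inhibitor. Compound 1, `O=C[C@H](CC(=O)O)NC(=O)c1cncc(S(=O)(=O)NC2CC2)c1`, gives 57000 nM in this assay. Compound 2, `CCN(CC)S(=O)(=O)c1cncc(C(=O)N[C@@H](CC(=O)O)C(=O)CSCc2ccc(F)cc2)c1`, gives 12000 nM in this assay. Going by the values given here, compound 2 thus stands at the lower of the two numbers, and its only neighbour, compound 1, sits at a higher number by a gap that lies beyond the usual scatter. Among the compounds with values here, compound 1 and compound 2 differ in several places at once, so no single step between measured compounds can be read off.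

Compound 3, `CN(C1CC1)S(=O)(=O)c1cncc(C(=O)N[C@@H](CC(=O)O)C(=O)CSCc2ccc(F)cc2)c1`, arises from compound 2 by one change: cyclopropyl(methyl)amino in place of diethylamino on a sulfonyl sulfur. The leaving and the entering group match in their count of heavy atoms and in carrying neither donors nor acceptors; the entering group adds one three-membered ring. Within the data shown here, no pair among the measured compounds isolates this exchange, so the measured numbers offer no direction for it. Compound 3 is therefore expected to land close to its starting point, with no change at the digits printed from compound 2 to compound 3 (within the scatter) expected to stay within the scatter. The estimate for compound 3 in this assay is 12000 nM, with a range from 4000 nM to 36000 nM.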

Compound 3, half-maximal inhibitory concentration: 22000 nM
Estimate against measurement, compound 3: 1.8-fold (0.26 log units) below; the measured number falls inside the stated range.
By their numbers in this assay, from the lowest: compounds 2 and 3 (each within the scatter of the next); then compound 1.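

In this assay, putting cyclopropyl(methyl)amino in place of diethylamino on a sulfonyl sulfur gives a 1.8-fold higher number from compound 2 to compound 3 (0.26 log units; within the scatter), so this exchange leaves compound 2 and compound 3 indistinguishable in the assay. Going by these compounds alone, this is the first measured pair that isolates this position, and it shows that a group with one three-membered ring and an open-chain group with the same count of heavy atoms can occupy the sulfonyl sulfur without a read-out separation beyond the scatter. Within the data shown here, nothing measured on these compounds accounts for this outcome, and the single step cannot say which features of either group matter.

From the compounds shown here alone, how far the sulfonyl sulfur tolerates groups of a different kind remains open, for example morpholine, piperidine or the longer dipropylamino chain, since one exchange between two groups of equal size marks out no trend for this position. Going by these compounds, it is also open whether this assay would respond more strongly to a change elsewhere on the shared core, such as chlorine in place of the fluorine on the aromatic ring.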